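The source may report more compounds than this note shows. Statements on the series, on what has been measured and on what is new or still open speak of the compounds shown alone.

Measured in an ADME assay on the whole organism with Oryza sativa as the target, tested at 1 uM; on this read-out higher numbers stand for a weaker effect at the one concentration tested and lower numbers for a stronger effect:
- compound 1 `Cc1cccc(NC(=O)N[C@@H](C)c2ccccc2)c1`: 100%
- compound 2 `CCc1ccc(NC(=O)N[C@H](C)c2ccccc2)cc1`: 47%
- compound 3 `CCc1ccc(NC(=O)N[C@@H](C)c2ccccc2)cc1`: 95%

Compound 2 stands lowest of the three numbers in this assay. The nearest number is that of compound 3, reached by a number 48 percentage points higher from compound 2 to compound 3 (beyond the scatter); this step rests on (the fact that compounds 2 and 3 differ only in the configuration as drawn), the two compounds being otherwise identical. Compound 1 lies furthest from compound 2, and compound 1 gives 100%.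

The next compound, compound 4 `C[C@@H](NC(=O)Nc1ccc(C(C)(C)C)cc1)c1ccccc1`, keeps the configuration drawn for compound 2 and differs from it by tert-butyl in place of ethyl on an aromatic carbon. Going by the values given here, no measured step in this set changes the group on the aromatic ring; the one step measured, from compound 2 to compound 3, concerns configuration only and does not bear on an exchange of substituent. Among the compounds with values here, with no comparable step in hand, the number for compound 4 is expected to stay within the scatter of that of compound 2, giving an estimated a number 8 percentage points higher from compound 2 to compound 4 (within the scatter). The estimate for compound 4 in this assay is therefore 55%, with an expected range from 25% to 95%.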

Compound 4, a percentage reported as activity, at one concentration (the size of the read-out at that concentration, not a potency): 88%
Estimate against measurement, compound 4: 33 percentage points below; the range from low to high includes it.
By their numbers in this assay, from the lowest: compound 2; then compounds 4, 3 and 1 (each within the scatter of the next, the first and the last beyond it).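

In this assay, the group on the aromatic carbon para to a large group matters on its own: with the drawn configuration held, tert-butyl in place of ethyl gives a number 41 percentage points higher from compound 2 to compound 4 (beyond the scatter). The earlier compounds shown here showed a large step only for a change of configuration; this one shows that a substituent exchange at this position can also produce a large step, here towards the weaker effect. Nothing measured in this set bears on the cause of this step.

As far as these compounds go, it remains open whether the number depends on the size of the group or on its branching, which a propyl chain, an isopropyl group or a methoxy group at this position could help separate. From the compounds shown here alone, it also remains open whether the configuration step seen with ethyl recurs with tert-butyl.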